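This account rests on a few compounds, and the source may have more. Where it says the series, first, only, none or still open, it means among the compounds named here.

Of the compounds shown here, two of a shared core have been tested in an ADME assay on MT4 cells (Homo sapiens) for cytotoxicity, read by MTT assay, with a stated time of 5 days; on this read-out lower numbers stand for higher toxicity in this test and higher numbers for lower toxicity in this test. Compound 1 `COc1cc2nc([S+]([O-])CC(=O)Nc3ccc(C(F)(F)F)cc3)nc(Nc3c(C)cc(/C=C/C#N)cc3C)c2cc1OC` gives 52200 nM in this assay. Compound 2 `COc1cc2nc([S+]([O-])CC(=O)Nc3ccc(Cl)cc3)nc(Nc3c(Cl)cc(/C=C/C#N)cc3Cl)c2cc1OC` gives 14400 nM in this assay, the lower of the two numbers, so compound 2 is the more toxic of the pair here. Compound 3 `COc1cc2nc([S+]([O-])CC(=O)Nc3ccc(C)cc3)nc(Nc3c(Cl)cc(/C=C/C#N)cc3Cl)c2cc1OC` differs from compound 2 by a single change: methyl in place of chloro on an aromatic carbon. Among the compounds with values here, no measured pair shows this change, so only a modest shift toward a higher number is expected, a step of a 1.4-fold higher number from compound 2 to compound 3 (0.14 log units; within the scatter) from compound 2 to compound 3. On this basis compound 3 is estimated at 20000 nM in this assay, within 8000 nM to 60000 nM.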

Compound 3, half-maximal cytotoxic concentration: 32200 nM
The estimate for compound 3 lay 1.6-fold (0.21 log units) below the measured number; the measured number falls inside the stated range.
By their numbers in this assay, from the lowest: compound 2; then compounds 3 and 1 (each within the scatter of the next).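

In this assay, within the data shown here, the change from 4-chlorophenyl to 4-methylphenyl gives a 2.2-fold higher number from compound 2 to compound 3 (0.35 log units; beyond the scatter), the first step that isolates a single change. It shows that this position alone can move the read-out beyond the scatter, with the methyl compound the less toxic in this test. Nothing available here accounts for that step. Trifluoromethyl at this position occurs only in compound 1, which also differs from compound 2 elsewhere, so its effect cannot be read. From the compounds shown here alone, how an amine or a carboxylic acid at this position would behave remains open.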